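Swapping methyl for chloro on the cyanopyridine

A few compounds are considered here, and "the series" means these few. Any claim that something is new, unique, unknown or untested is made for them only; others in the source may bear on it.

Measured so far in an ADME assay on the whole organism (Mus musculus, strain CD1) for pharmacokinetics, at a dose of 2 mg/kg by the intravenous route; on this read-out higher numbers stand for wider distribution into tissues and lower numbers for narrower distribution:
compound 1 `Cc1cc(N2C(=O)C3(CCC3)N(c3ccc(OC4CCNCC4)nc3)C2=S)cnc1C#N`: 4.35 L/kg
compound 2 `N#Cc1ncc(N2C(=O)C3(CCC3)N(c3ccc(CN4CCNCC4)cc3)C2=S)cc1C(F)(F)F`: 16.8 L/kg

Compound 1 stands at the lower of the two numbers, at 4.35 L/kg, while compound 2 reads higher, at 16.8 L/kg, a gap beyond the scatter. The next compound to be measured is compound 3 `N#Cc1ncc(N2C(=O)C3(CCC3)N(c3ccc(OC4CCNCC4)nc3)C2=S)cc1Cl`. It carries chloro in place of methyl on an aromatic carbon of compound 1, turning 6-cyano-5-methylpyridin-3-yl into 5-chloro-6-cyanopyridin-3-yl (chloro in place of methyl on an aromatic carbon). Within the data shown here, no measured pair shows this exchange, so the data offer no direct guide to its size in this assay. The expectation therefore rests on compound 1 at 4.35 L/kg. The estimated step of a 1.0-fold higher number from compound 1 to compound 3 (0.01 log units; within the scatter) is expected to stay within the scatter, with no direction favoured. For compound 3 the expected value is 4.5 L/kg, with an estimated range of 2.2 L/kg to 9 L/kg.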

Compound 3, volume of distribution at steady state: 6.92 L/kg
Beside the measured number, compound 3's estimate is 1.5-fold (0.19 log units) below it; low and high end bracket the measured number.
By their numbers in this assay, from the lowest: compounds 1 and 3 (each within the scatter of the next); then compound 2.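

Among these compounds, this is the first measured pair in which only the group on this aromatic carbon, ortho to a cyano group and two atoms from the ring nitrogen, is exchanged. In this assay, chloro in place of methyl gives a 1.6-fold higher number from compound 1 to compound 3 (0.20 log units; within the scatter), so the pair does not separate these two groups at this position, at least on the core of compound 1. No measured information bears on what lies behind the size of this step.

The compounds shown leave open whether a group of a different kind at this position, such as an amine or a methoxy group, would move the read-out beyond the scatter. They also leave open whether chloro in place of methyl would give a similar step on a core carrying a different large group.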